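Aryl amine variation on a methylpiperazinyl-propoxy quinoline core

A few compounds are considered here, and "the series" means these few. Any claim that something is new, unique, unknown or untested is made for them only; others in the source may bear on it.

Measured compounds:
- compound 1, `CN1CCN(CCCOc2cccc3nc(Nc4ccc(Cl)c(C(F)(F)F)c4)ccc23)CC1`: 1620 nM in a functional assay on cells (Panel NCI-60 (60 carcinoma cell lines), Homo sapiens) for inhibition, read by sulforhodamine B assay, with a stated time of 48 h; a higher number here means a weaker inhibitor of growth, a lower number a stronger inhibitor of growth
- compound 2, `CN1CCN(CCCOc2cccc3nc(Nc4ccc(F)c(F)c4)ccc23)CC1`: 2630 nM

In this assay, among the measured compounds shown here, compound 2 gives the highest number of the two measured, and its only neighbour is compound 1; the step of a 1.6-fold higher number from compound 1 to compound 2 (0.21 log units; within the scatter) is within the scatter, so the two compounds cannot be separated on these numbers.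

Compound 3, `CN1CCN(CCCOc2cccc3nc(Nc4cccc(Cl)c4)ccc23)CC1`, is not yet measured. The change from compound 2 is 3-chlorophenyl in place of 3,4-difluorophenyl on a nitrogen on an aromatic ring. For the measured compounds named here, the only measured step that bears on a change at this nitrogen is the one from compound 1 to compound 2, and it stayed within the scatter. No basis exists in the measured pair for expecting compound 3 to move beyond the scatter in either direction in this assay; the step of a 1.2-fold lower number from compound 2 to compound 3 (0.08 log units; within the scatter) is expected to be small. Compound 3 is therefore estimated at 2200 nM in this assay, with a range from 900 nM to 5500 nM.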

Compound 3, concentration for 50% growth inhibition: 1910 nM
Beside the measured number, compound 3's estimate is 1.2-fold (0.06 log units) above it; measured number inside the range.
By their numbers in this assay, from the lowest: compounds 1, 3 and 2 (each within the scatter of the next).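

In this assay, both new steps stay within the scatter: (a 1.4-fold lower number from compound 2 to compound 3 (0.14 log units; within the scatter)) and (a 1.2-fold higher number from compound 1 to compound 3 (0.07 log units; within the scatter)). With 3-chlorophenyl added, three different halogen-bearing phenyl groups on this nitrogen now give values that cannot be separated, so the flat reading from the first pair extends to a third group, and no order can be drawn among compounds 1, 2 and 3. Nothing at hand bears on why these changes leave the number within the scatter.

The compounds shown leave open whether a phenyl group without halogen, such as 4-methoxyphenyl, or a pyridine ring on this nitrogen would move the number beyond the scatter. Also open, on these data alone, is whether the same holds for changes elsewhere, such as a morpholine in place of the methylpiperazine or a longer chain in place of the propoxy link.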